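The source may hold more compounds than are shown below. What is called first, only, known or untested is meant among the compounds shown, and "the series" means these compounds.

In a functional assay on SGC-7901 cells (Homo sapiens) for inhibition, read by MTT assay, with a stated time of 72 h (a higher number here means a weaker inhibitor of growth, a lower number a stronger inhibitor of growth), compound 1 `COC1=C(OC)C(=O)C(CCCCCCn2cc(C[C@H](O)COCCOC[C@@H](O)Cc3ccc(-c4ccccc4)cc3)nn2)=C(C)C1=O` gives 16700 nM and compound 2 `O=C1COc2ccc(-n3cc(C[C@H](O)COCCOC[C@@H](O)Cc4ccc(-c5ccccc5)cc4)nn3)cc2N1` gives 15200 nM. For the measured compounds named here, these two values lie within the scatter of each other, so compound 2 stands level with compound 1 on the numbers so far. Compound 3 `O[C@H](COCCOC[C@@H](O)Cc1c[nH]nn1)Cc1ccc(-c2ccccc2)cc1` differs from compound 2 as follows: a hydrogen atom in place of a group of 11 heavy atoms (8 carbon, 1 nitrogen, 2 oxygen; one six-membered non-aromatic ring with 2 hetero atoms, one six-membered aromatic ring of carbon only), on an aromatic nitrogen. In words, a hydrogen atom takes the place of that whole group, on an aromatic nitrogen. Going by the values given here, no measured pair shows what such a large removal does, so the expectation here is loose. A modest rise in the number is expected, meaning a somewhat weaker inhibitor of growth, slightly beyond the scatter. The estimated change is a 1.8-fold higher number from compound 2 to compound 3 (0.27 log units; within the scatter). For compound 3 the expected value is 28000 nM, with an estimated range from 11000 nM to 70000 nM.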

Compound 3, concentration for 50% growth inhibition: > 100000 nM
Compound 3: no number, only a limit; the forecaster's own chance of this, stated with the estimate: 20%; at least 3.5-fold (0.55 log units) between middle value and limit.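

Taking the whole group off the aromatic nitrogen and leaving a hydrogen atom there does real harm to growth inhibition in this assay, with an at least 6.5-fold higher number from compound 2 to compound 3 (0.81 log units; beyond the scatter). Compound 3 gives only a limit of the assay, not a number, so the full size of this step stays unknown: the limit of > 100000 nM in this assay, at which 1 of the 3 values shown sits.

The earlier values could not show this: compound 1 at 16700 nM and compound 2 at 15200 nM lie within the scatter of each other, and both carry a large group on this nitrogen, although the two groups differ, so only compound 3 shows this nitrogen with a hydrogen atom.

On these data alone, how much of the large group is needed remains open. A single methyl group, a plain hexyl chain or a short chain ending in an amine on this nitrogen could each help to settle that.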